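A few compounds are considered here, and "the series" means these few. Any claim that something is new, unique, unknown or untested is made for them only; others in the source may bear on it.

Two compounds of the series have numbers in a functional assay on PC-3 cells (Homo sapiens) for cytotoxicity, read by MTT assay, with a stated time of 48 h (on this read-out lower numbers stand for stronger inhibition and higher numbers for weaker inhibition), so far. Compound 1 `CCN(CC)CC(=O)N1N=C(C)CC1c1ccccc1OC(C)=O` gives 51200 nM in this assay. Compound 2 `O=C(CNC1CC1)N1N=C(c2cc3ccccc3oc2=O)CC1c1ccccc1` gives 28500 nM in this assay, the lowest of the two numbers shown, though the gap to compound 1 lies within the scatter, so the two are not told apart. Within the data shown here, no step between two measured compounds that differ in one place is available, so the series offers no measured guide for a single change. Compound 3 `CN1CCN(CC(=O)N2N=C(c3cc4ccccc4oc3=O)CC2c2ccccc2)CC1` is not yet measured in this assay and differs from compound 2 as follows: 4-methylpiperazin-1-yl in place of cyclopropylamino on a saturated chain carbon bound to a carbonyl carbon on a saturated chain carbon bound to a carbonyl carbon, the rest of the shared core being kept. Among the measured compounds shown here, with no measured step to rest on, the expectation for compound 3 is a step from compound 2 of about a 1.1-fold lower number from compound 2 to compound 3 (0.04 log units; within the scatter) in this assay, that is, none beyond the scatter in either direction. Compound 3 is therefore estimated at 26000 nM in this assay, with a range from 8000 nM to 85000 nM around it.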

Compound 3, half-maximal inhibitory concentration: 25800 nM
Compound 3: the middle estimate sits 1.0-fold (0.00 log units) above what was measured, within the range that was stated.
By their numbers in this assay, from the lowest: compounds 3, 2 and 1 (each within the scatter of the next).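

Among these compounds, the exchange of cyclopropylamino for 4-methylpiperazin-1-yl on a saturated chain carbon bound to a carbonyl carbon gives a 1.1-fold lower number from compound 2 to compound 3 (0.04 log units; within the scatter) in this assay, the first measured step for a single change. The entering group has 7 heavy atoms against 4, a six-membered non-aromatic ring with 2 hetero atoms in place of a three-membered ring of carbon only, and 0 hydrogen-bond donors against 1, yet this read-out does not tell compound 2 and compound 3 apart. No supporting measurement bears on this result.

On these data alone, whether any group at this place can move the number beyond the scatter remains open, as only two amines can be compared here; a carboxylic acid, a hydroxyl group or a longer chain ahead of the amine would test this. As far as these compounds go, compound 1 differs from compound 2 and compound 3 in more than one place, so what the other parts of the structure contribute in this assay also remains open.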